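Sulfonyl aryl replacement in the piperidinyl-piperidine sulfonamide series

The source may hold more compounds than are shown below. What is called first, only, known or untested is meant among the compounds shown, and "the series" means these compounds.

Measured so far, all in a functional assay on DLD-1 cells (Homo sapiens) for antiproliferative activity, read by CellTiter-Glo, with a stated time of 72 h; on this read-out lower numbers stand for stronger inhibition and higher numbers for weaker inhibition:
compound 1, `CC1CCN(C2CCN(S(=O)(=O)c3cccc(Br)c3)CC2)CC1`: 3.2 nM
compound 2, `CC1CCN(C2CCN(S(=O)(=O)c3cccc(C(F)(F)F)c3)CC2)CC1`: > 5000 nM, a limit of this assay
compound 3, `CC1CCN(C2CCN(S(=O)(=O)c3cccc(-c4ccc5ccccc5c4)c3)CC2)CC1`: 2 nM

Compound 1 and compound 3 lie within the scatter of each other, the step being a 1.6-fold lower number from compound 1 to compound 3 (0.20 log units; within the scatter). Compound 2 reports only a limit, (the limit of > 5000 nM in this assay, at which 1 of the 3 values shown sits). The two steps touching compound 2 are large: an at least 1500-fold higher number from compound 1 to compound 2 (3.19 log units; beyond the scatter) and an at least 2500-fold lower number from compound 2 to compound 3 (3.39 log units; beyond the scatter). So the group on the sulfonyl aryl ring sets the whole range seen here, from naphthalen-2-yl or bromo, which give low numbers, to trifluoromethyl, which gives only a limit.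

Compound 4, `CC1CCN(C2CCN(S(=O)(=O)c3cccnc3)CC2)CC1`, is not yet measured. Its change from compound 1 is pyridin-3-yl in place of 3-bromophenyl on a sulfonyl sulfur. For the measured compounds named here, no measured step swaps the whole aryl ring or brings in a ring nitrogen, so the bearing of the three steps is indirect: they show that this position tolerates wide change yet can also lose all activity. Losing bromo without a replacing substituent is expected to cost something, in the direction of a higher number, with a wide range. Compound 4 is thus expected at 100 nM, between 10 nM and 2000 nM. The expected step is a 31-fold higher number from compound 1 to compound 4 (1.49 log units; beyond the scatter).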

Compound 4, half-maximal inhibitory concentration: 2400 nM
Compound 4: middle estimate off by 24-fold (1.38 log units), on the low side; measured number outside the range, above it.
By their numbers in this assay, from the lowest: compounds 3 and 1 (each within the scatter of the next); then compound 4. At a limit, above all of these: compound 2.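

In this assay, pyridin-3-yl in place of 3-bromophenyl on the sulfonyl sulfur is a large loss: a 750-fold higher number from compound 1 to compound 4 (2.88 log units; beyond the scatter). Earlier large steps came from swapping only the substituent on the aryl ring, whereas this one shows that replacing the whole aryl group, with bromo leaving and a ring nitrogen entering, also moves the number far beyond the scatter. Compound 4 gives a measured number, while compound 2 remains a limit and not a number: the limit of > 5000 nM in this assay, at which 1 of the 4 values shown sits.

This step changes the ring atom and removes bromo together, so the two changes cannot be separated; unsubstituted phenyl or a bromo-bearing pyridine would separate them. As far as these compounds go, it also remains open whether chloro, methoxy or an amine in place of bromo would track bromo or trifluoromethyl.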